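Swapping nitro for amino on a second biaryl core

The source may report more compounds than this note shows. Statements on the series, on what has been measured and on what is new or still open speak of the compounds shown alone.

Compound 1 `CCOC(=O)c1cccc(-c2ccc(OCC)c([N+](=O)[O-])c2)c1` gives 44% in an assay on COS-7 cells for inhibition of patatin-like phospholipase domain-containing protein 2 (Mus musculus), tested at 200 uM; a higher number here means more inhibition at the concentration tested (going by the name of the read-out), a lower number less inhibition.
Compound 2 `CCOC(=O)c1cccc(-c2ccc(OCC)c(N)c2)c1` gives 59% in this assay.
Compound 3 `CN(C)c1ccc(-c2cccc([N+](=O)[O-])c2)cc1` gives 21% in this assay.

Compound 4 `CN(C)c1ccc(-c2cccc(N)c2)cc1` has not yet been measured. It differs from compound 3 by a single change: amino in place of nitro on an aromatic carbon. The same kind of change links compound 1 to compound 2: amino in place of nitro on an aromatic carbon. There the change produced a step of a number 15 percentage points higher from compound 1 to compound 2 (beyond the scatter). The surroundings of the place are not identical, however: in compound 1 the place is ortho to an ethoxy group (3 heavy atoms) and meta to a large group, whereas in compound 3 it is meta to a group of 9 heavy atoms. The difference between the two cores themselves is not broken down here. Among the three measured compounds, compound 3 has the lowest value, and both others lie beyond the usual scatter above it. Because the earlier step was a number 15 percentage points higher from compound 1 to compound 2 (beyond the scatter), a step of similar size is expected here: a number 15 percentage points higher from compound 3 to compound 4 (beyond the scatter). Compound 4 is therefore estimated at 36%, with a likely range from 18% to 52%.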

Compound 4, a percentage reported as inhibition, at one concentration (the size of the read-out at that concentration, not a potency): 70%
For compound 4 the middle estimate is 34 percentage points below the measured one; the measured number lies above the stated range.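

In this assay amino in place of nitro on the second core gives a number 49 percentage points higher from compound 3 to compound 4 (beyond the scatter) and so moves the number in the same direction as on the first core. The size of the step, however, does not carry over from one core to the other: the same change on two cores in this assay, a number 15 percentage points higher (beyond the scatter) from compound 1 to compound 2 and a number 49 percentage points higher (beyond the scatter) from compound 3 to compound 4, 34 percentage points apart, beyond the scatter of two such steps

For these two pairs, then, the direction of the change held while its size depended on the core, so a step read on one core is a poor guide to the exact number on another; two pairs cannot show why the sizes differ or predict the step on a third core.

On these data alone, it remains open whether a different group on the same aromatic carbon, such as a hydroxyl or an acetamide, would follow the amino group or the nitro group. As far as these compounds go, it is also open how far the step would hold if the dimethylamino group of compound 4 gave way to a carboxylic acid or a longer chain.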